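From compound 2 to compound 3 in a solubility series

The source may hold more compounds than are shown below. What is called first, only, known or untested is meant among the compounds shown, and "the series" means these compounds.

Of the compounds shown here, two of one series have been measured in a physicochemical assay for solubility, in phosphate buffer, measured as kinetic solubility, with a stated time of 1 h, at pH 7.4; on this read-out higher numbers stand for higher solubility and lower numbers for lower solubility. Compound 1 `CSc1ccc2nc(C)cc(OCC(=O)Nc3cc(C)cc(C)c3)c2c1` gives 3000 nM in this assay. Compound 2 `COc1ccc2nc(C)cc(OCC(=O)Nc3cc(C)ccc3OC)c2c1` gives 9500 nM in this assay, the higher of the two numbers; its nearest neighbour is compound 1, whose number is lower by a margin beyond the scatter. Going by the values given here, no pair of the measured compounds differs in only one place, so no single step can be read directly from these two.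

Compound 3 `COc1ccc2nc(C)cc(OCC(=O)NNC(=O)c3ccncc3)c2c1` has not yet been measured. It differs from compound 2 in one place: ((pyridin-4-yl)carbonyl)amino in place of 2-methoxy-5-methylphenyl on an amide-type nitrogen. The measured numbers of compound 1 and compound 2 do not fix the size of such a change, and what follows rests on the structural change alone. The expected step is a 3.2-fold higher number from compound 2 to compound 3 (0.50 log units; beyond the scatter), upward and beyond the scatter. The estimate for compound 3 in this assay is 30000 nM, with a range from 10000 nM to 90000 nM.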

Compound 3, solubility: >= 375000 nM
Compound 3 was reported as a limit (the forecaster's own chance of this, stated with the estimate: 10%); middle value at least 12-fold (1.09 log units) away from the limit.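

In this assay compound 3 gives >= 375000 nM, which is a limit of the assay and not a number. Going by these compounds alone, with this, the first single step can be read, and it is large: an at least 39-fold higher number from compound 2 to compound 3 (1.59 log units; beyond the scatter), for ((pyridin-4-yl)carbonyl)amino in place of 2-methoxy-5-methylphenyl on the amide-type nitrogen whose other neighbour is the carbonyl carbon. Compound 1 and compound 2 differ in more than one place and could not show this, and the new step shows that a change at this one position can move this assay far beyond the scatter, even though both groups hold the same count of heavy atoms and neither carries a net charge.

How far the step really reaches stays open, and the limit gives only its lower bound: the limit of >= 375000 nM in this assay, at which 1 of the 3 values shown sits.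

The compounds shown also leave open which part of the entering group goes with the step, the pyridin-4-yl ring, the carbonyl or the added amino nitrogen, and a benzoyl group or an acetyl group on the same nitrogen would separate these parts.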